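Methyl for Phenyl on an Aromatic Nitrogen of the Core

The source may hold more compounds than are shown below. What is called first, only, known or untested is meant among the compounds shown, and "the series" means these compounds.

Compound 1 `COC1Cc2c(cnn2-c2ccccc2)C2(CCN(CCCc3ccccc3)CC2)O1` is characterised in an assay for displacement of a labelled ligand from Sigma non-opioid intracellular receptor 1 (Cavia porcellus), read by scintillation counting, with a stated time of 180 min (a lower number here means a stronger inhibitor, a higher number a weaker inhibitor), where compound 1 gives 3.2 nM. Its only measured companion, compound 2 `COC1Cc2c(cnn2-c2ccccc2)C2(CCN(CC(C)C)CC2)O1`, gives 6.3 nM in this assay, and the step between them is a 2.0-fold higher number from compound 1 to compound 2 (0.29 log units; within the scatter). Of the two numbers, that of compound 1 is the smaller, yet the gap to compound 2 is within the usual scatter, so the pair count as equivalent.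

Compound 3 `COC1Cc2c(cnn2C)C2(CCN(CCCc3ccccc3)CC2)O1` differs from compound 1 by methyl in place of phenyl on an aromatic nitrogen. For the measured compounds named here, no measured step touches this position: the single known step, a 2.0-fold higher number from compound 1 to compound 2 (0.29 log units; within the scatter), alters the group on the amine nitrogen in a ring and stays within the scatter, so it says nothing about how this part of the shared core responds. With no anchor for direction, compound 3 is expected to show a modest weakening, a step of a 2.5-fold higher number from compound 1 to compound 3 (0.40 log units; beyond the scatter) in this assay. Compound 3 is therefore estimated at 8 nM, with a plausible range from 2 nM to 30 nM.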

Compound 3, inhibition constant: 93 nM
Beside the measured number, compound 3's estimate is 12-fold (1.07 log units) below it; measured number outside the range, above it.
By their numbers in this assay, from the lowest: compounds 1 and 2 (each within the scatter of the next); then compound 3.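

For the compounds shown here, the phenyl on the aromatic nitrogen matters far more than the earlier compounds could show: in this assay replacing it with methyl gives a 29-fold higher number from compound 1 to compound 3 (1.46 log units; beyond the scatter), a large step. Going by these compounds alone, the only earlier step, a 2.0-fold higher number from compound 1 to compound 2 (0.29 log units; within the scatter), changed the group on the amine nitrogen and stayed within the scatter, so this is the first sign that the number responds strongly to a change on the shared core. No available evidence explains this large step.

As far as these compounds go, only phenyl and methyl appear on this nitrogen, so it remains open whether the aromatic ring itself counts or simply the larger group of carbons. A cyclohexyl group or a longer chain such as butyl on the same nitrogen would help separate those two readings.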